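The compounds below may be only part of what the source reports. "The series", "measured", "known", "first", "only" and "open" are said of these compounds alone.

Compound 1 `CN1CCN(CCCCOc2c(O)cc(O)c3c(=O)cc(-c4ccccc4)oc23)CC1`: > 100000 nM
Compound 2 `CC(C)NCCCCOc1c(O)cc(O)c2c(=O)cc(-c3ccccc3)oc12`: "not determined" (no result reported)

In a functional assay on A549 cells (Homo sapiens) for cytotoxicity, read by MTT assay, with a stated time of 48 h (on this read-out higher numbers stand for weaker inhibition and lower numbers for stronger inhibition), the entry for compound 1 is a limit and not a number. Compound 2 has no result, so it holds no place on the scale. Among the measured compounds shown here, the only reading so far is the limit of > 100000 nM in this assay, at which 1 of the 2 values shown sits.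

Compound 3 `O=c1cc(-c2ccccc2)oc2c(OCCCN3CCCC3)c(O)cc(O)c12` carries this change: pyrrolidin-1-yl in place of (isopropylamino)methyl on a saturated chain carbon, three bonds along the chain from an oxygen on an aromatic ring. It has pyrrolidin-1-yl in place of (isopropylamino)methyl on a saturated chain carbon, three bonds along the chain from an oxygen on an aromatic ring.

Compound 1 shares the core, and with the limit of > 100000 nM in this assay, at which 1 of the 2 values shown sits, as the only anchor, just a small step towards stronger inhibition is expected in this assay. For compound 3 the estimated value is 60000 nM, with an expected range from 15000 nM to 150000 nM.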

Compound 3, half-maximal inhibitory concentration: > 100000 nM
Compound 3 was reported as a limit; the forecaster's own chance of this, stated with the estimate: 50%; middle value at least 1.6-fold (0.22 log units) from the limit.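

Among the compounds shown here, compound 1 and compound 3 both stand at a limit in this assay, and no step between them can be read. The compounds shown leave open what number either would reach on this scale and where compound 2 stands.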